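Working notes: the step from compound 3 to compound 4

The source may hold more compounds than are shown below. What is called first, only, known or untested is meant among the compounds shown, and "the series" means these compounds.

Values in a functional assay on A549 cells (Homo sapiens) for cytotoxicity, read by MTT assay, with a stated time of 72 h; a higher number here means a weaker inhibitor, a lower number a stronger inhibitor:
- compound 1 `N#Cc1ccc(/C=N/NC(=O)Nc2cc3c(Nc4ccc(F)c(Cl)c4)ncnc3cc2O[C@H]2CCOC2)cc1`: 29100 nM
- compound 2 `COc1cc2ncnc(Nc3ccc(F)c(Cl)c3)c2cc1NC(=O)N/N=C/c1ccc(F)cc1`: 26600 nM
- compound 3 `COc1cc2ncnc(Nc3ccc(F)c(Cl)c3)c2cc1NC(=O)N/N=C/c1ccc(C#N)cc1`: 32200 nM

In this assay compound 3 gives 32200 nM, within the scatter of both other compounds. Compound 4 `COc1cc2ncnc(Nc3ccc(F)c(Cl)c3)c2cc1NC(=O)N/N=C/c1ccc(F)cc1Cl` has 2-chloro-4-fluorophenyl in place of 4-cyanophenyl on a carbon with a double bond to nitrogen. Among the measured compounds shown here, two measured steps bear on it. With cyano in place of fluoro on an aromatic carbon, the data show a 1.2-fold higher number from compound 2 to compound 3 (0.08 log units; within the scatter). With methyl in place of oxolan-3-yl on an oxygen on an aromatic ring, they show a 1.1-fold higher number from compound 1 to compound 3 (0.04 log units; within the scatter). For the measured compounds named here, no measured compound carries the chloro group, so that part remains untested. Neither measured step leaves the scatter, so no change beyond it is expected in this assay. The estimate means a 1.2-fold lower number from compound 3 to compound 4 (0.06 log units; within the scatter). Compound 4 is expected at 28000 nM, with an estimated range of 14000 nM to 55000 nM.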

Compound 4, half-maximal inhibitory concentration: 28200 nM
For compound 4 the middle estimate is 1.0-fold (0.00 log units) below the measured one; the range from low to high includes it.
By their numbers in this assay, from the lowest: compounds 2, 4, 1 and 3 (each within the scatter of the next).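

In this assay, 2-chloro-4-fluorophenyl in place of 4-cyanophenyl on the carbon with a double bond to nitrogen stays within the scatter (a 1.1-fold lower number from compound 3 to compound 4 (0.06 log units; within the scatter)). The chloro group, untested until now, also leaves the number within the scatter (a 1.1-fold higher number from compound 2 to compound 4 (0.03 log units; within the scatter)), so this position has now taken a nitrile, a fluoro group and a chloro group with no change beyond it. No available evidence bears on the reason for this. From the compounds shown here alone, whether an amine or a carboxylic acid on this aromatic ring, or a longer chain in its place, would move the number beyond the scatter stays open.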